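Shortening a selenocyanate linker in a quinazoline series

The source may report more compounds than this note shows. Statements on the series, on what has been measured and on what is new or still open speak of the compounds shown alone.

Measured compounds:
compound 1 `Cc1nc(N(C)c2ccc([Se]C#N)c(F)c2)c2ccccc2n1` – 37 nM
compound 2 `COc1ccc(N(C)c2nc(C)nc3ccccc23)cc1OCCCCCC[Se]C#N` – 4890 nM

In a functional assay on HepG2 cells (Homo sapiens) for inhibition, read by MTT assay, with a stated time of 48 h (a higher number here means a weaker inhibitor, a lower number a stronger inhibitor), compound 1 gives 37 nM, while compound 2 gives 4890 nM. Compound 2 has the highest number of the two, and the gap to compound 1 lies well beyond the scatter. Compound 3 `COc1ccc(N(C)c2nc(C)nc3ccccc23)cc1OCC[Se]C#N` has not yet been measured. It differs from compound 2 as follows: a group of 3 heavy atoms (1 carbon, 1 nitrogen, 1 selenium; no ring) in place of a group of 7 heavy atoms (5 carbon, 1 nitrogen, 1 selenium; no ring), on a saturated chain carbon, two bonds along the chain from an oxygen on an aromatic ring. The change is a group of 3 heavy atoms in place of a group of 7 heavy atoms, on a saturated chain carbon, two bonds along the chain from an oxygen on an aromatic ring. Going by the values given here, no step between measured compounds of this kind is available, so the expectation rests only on the two values shown. A moderate decrease is expected in this assay, since compound 1 gives 37 nM. Compound 3 is estimated at 1500 nM, with a range from 300 nM to 8000 nM. The expected step of a 3.3-fold lower number from compound 2 to compound 3 (0.51 log units; beyond the scatter) points toward a stronger inhibitor.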

Compound 3, half-maximal inhibitory concentration: 14 nM
Estimate against measurement, compound 3: 110-fold (2.03 log units) above; measured number outside the range, below it.
By their numbers in this assay, from the lowest: compound 3; then compound 1; then compound 2.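

In this assay, the group of 3 heavy atoms in place of the group of 7 heavy atoms gives a 350-fold lower number from compound 2 to compound 3 (2.54 log units; beyond the scatter) and this marks the position, on a saturated chain carbon, two bonds along the chain from an oxygen on an aromatic ring, as highly responsive to the length of what it carries. The earlier compounds shown here differ in more than one place and could not isolate this change, whereas this pair keeps the shared core and the selenocyanate end the same. Nothing given here accounts for the lower number that comes with the shorter chain.

With only two chain lengths shown on this core, it remains open whether the number changes gradually or abruptly with length, and a chain of intermediate length would help to settle this. From the compounds shown here alone, it also remains open how much depends on the selenium, which a thiocyanate end on the same short chain would test.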